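The compounds below may be only part of what the source reports. "The series", "measured", "known", "first", "only" and "open" are said of these compounds alone.

Compounds measured in a functional assay on SGC-7901 cells (Homo sapiens) for cytotoxicity, read by MTT assay, with a stated time of 48 h; a lower number here means a stronger inhibitor, a higher number a weaker inhibitor:

- compound 1 `CC1=NN(C(=O)CN2CCC(O)CC2)C(c2ccccc2O)C1` gives 5710 nM
- compound 2 `CC1=NN(C(=O)CN2CCCCC2[N+](=O)[O-])C(c2ccccc2O)C1` gives 30700 nM
- compound 3 `CCC1CCCCN1CC(=O)N1N=C(c2cc3ccccc3oc2=O)CC1c1ccccc1` gives 6000 nM

Among these three, compound 3 at 6000 nM lies within the scatter of compound 1 at 5710 nM. Compound 2 at 30700 nM carries a number well beyond the scatter above that of compound 3 , making it the weakest of the set in this assay.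

Compound 4 `CC1CCN(CC(=O)N2N=C(c3cc4ccccc4oc3=O)CC2c2ccccc2)CC1` has not yet been measured. It differs from compound 3 by one exchange, 4-methylpiperidin-1-yl in place of 2-ethylpiperidin-1-yl on a saturated chain carbon bound to a carbonyl carbon.

Among the compounds with values here, no measured pair in this small set differs in only one place, so the data give no direct guide to the size of such a step. The ring kind stays the same, and only the alkyl group and its place on the ring change. The expectation therefore stays close to compound 3 at 6000 nM, with no shift beyond the scatter in either direction. The expected change is a 1.2-fold higher number from compound 3 to compound 4 (0.07 log units; within the scatter). For compound 4 the estimated value is 7000 nM, with an expected range from 2500 nM to 20000 nM.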

Compound 4, half-maximal inhibitory concentration: 4700 nM
For compound 4 the middle estimate is 1.5-fold (0.17 log units) above the measured one; the measured number falls inside the stated range.
By their numbers in this assay, from the lowest: compounds 4, 1 and 3 (each within the scatter of the next); then compound 2.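

In this assay, within the data shown here, the exchange of 2-ethylpiperidin-1-yl for 4-methylpiperidin-1-yl gives the first step in this set that can be read at a single place: a 1.3-fold lower number from compound 3 to compound 4 (0.11 log units; within the scatter), which stays within the usual scatter of the assay. On a saturated chain carbon bound to a carbonyl carbon, the alkyl group and its place on the ring can therefore both change, for this pair, without the number moving beyond that scatter. Nothing measured alongside these numbers bears on the reason for this result.

This single pair leaves open whether the position would respond in the same way to a group of a different kind, such as morpholin-4-yl or piperazin-1-yl, or to a carboxylic acid on the ring in place of the alkyl group. Among these compounds, it also leaves open whether the same exchange would give a similar step on the core of compound 1, since only this one pair of compounds differs in just one place.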